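Aryl amide variation on the shared core

The compounds below may be only part of what the source reports. "The series", "measured", "known", "first", "only" and "open" are said of these compounds alone.

Three compounds share one core and differ only in the group on one amide nitrogen of that core. Compound 1 `CC(C)C(NS(=O)(=O)Cc1ccccc1)C(=O)N1CCC(c2ccc(Cl)cc2)CC1` carries a benzylsulfonyl group there; in an assay on THP-1 cells for displacement of a labelled ligand from C-C chemokine receptor type 1 (Homo sapiens) (on this read-out higher numbers stand for weaker inhibition and lower numbers for stronger inhibition), compound 1 gives 303 nM. Compound 2 `Cc1ccc(C(=O)N[C@@H](C(=O)N2CCC(c3ccc(Cl)cc3)CC2)C(C)C)cc1` carries a 4-methylphenyl carbonyl instead, and in this assay compound 2 gives 25 nM. Compound 3 `CC(C)[C@@H](NC(=O)c1nc2ccccc2s1)C(=O)N1CCC(c2ccc(Cl)cc2)CC1` carries a 1,3-benzothiazol-2-yl carbonyl, and in this assay compound 3 gives 18 nM, the lowest of the three numbers; the step of a 1.4-fold lower number from compound 2 to compound 3 (0.14 log units; within the scatter) lies within the scatter, whereas the number of compound 1 stands far from that of compound 3, well beyond the scatter.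

Compound 4 `CC(C)[C@@H](NC(=O)c1cccc(F)c1)C(=O)N1CCC(c2ccc(Cl)cc2)CC1` differs from compound 3 by 3-fluorophenyl in place of 1,3-benzothiazol-2-yl on a carbonyl carbon. Within the data shown here, the single measured step that bears on this change is the other aryl exchange on the same carbonyl carbon, a 1.4-fold lower number from compound 2 to compound 3 (0.14 log units; within the scatter), which lies within the scatter. Among the measured compounds shown here, compound 4 returns to a phenyl-type group as in compound 2, with a fluorine where compound 2 has a methyl; no measured step speaks to that fluorine. Given two aryl amides within scatter of each other, the expected step is a 1.7-fold higher number from compound 3 to compound 4 (0.22 log units; within the scatter), not beyond the scatter. The estimate for compound 4 in this assay is 30 nM, with a range of 12 nM to 80 nM.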

Compound 4, half-maximal inhibitory concentration: 24 nM
Compound 4: middle estimate off by 1.3-fold (0.10 log units), on the high side; low and high end bracket the measured number.
By their numbers in this assay, from the lowest: compounds 3, 4 and 2 (each within the scatter of the next); then compound 1.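

Exchanging the 1,3-benzothiazol-2-yl group for 3-fluorophenyl on a carbonyl carbon gives a 1.3-fold higher number from compound 3 to compound 4 (0.12 log units; within the scatter) in this assay and shows that, in this pair, the five-membered aromatic ring with its hetero atoms is not needed for a number in this range. The further comparison gives a 1.0-fold lower number from compound 2 to compound 4 (0.02 log units; within the scatter) and shows that 3-fluorophenyl cannot be told apart from 4-methylphenyl here, so the three aryl groups on this carbonyl carbon now form a set within the scatter of one another, with the benzylsulfonyl group of compound 1 at 303 nM standing apart from that set. No measurement on hand explains why these aryl exchanges leave the read-out within the scatter.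

Still open, as far as these compounds go, is whether an aromatic ring is needed on this carbonyl carbon at all, since a cyclohexyl group, a longer alkyl chain, or an aryl group carrying an amine or a carboxylic acid would test the limits of this tolerance. The effect of the fluorine itself also stays open, as the unsubstituted phenyl amide does not appear among these compounds.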